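Imidazolyl in Place of Diethylamino: an Expected Loss

The compounds below may be only part of what the source reports. "The series", "measured", "known", "first", "only" and "open" are said of these compounds alone.

Compound 1 `CC(C)(C)NCCC(c1ccccc1)c1ccccc1`: 792 nM
Compound 2 `CCN(CC)CCC(c1ccccc1)c1ccccc1`: 197 nM

Of the compounds shown here, two have so far been measured in an assay on ileum with muscarinic acetylcholine receptor M3 (Cavia porcellus) as the target; on this read-out higher numbers stand for weaker inhibition and lower numbers for stronger inhibition. Compound 1 gives 792 nM, and compound 2 gives 197 nM. Among the measured compounds shown here, compound 2 thus stands with the lower of the two numbers, and the single measured step, a 4.0-fold lower number from compound 1 to compound 2 (0.60 log units; beyond the scatter), separates them.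

Compound 3 `c1ccc(C(CCn2ccnc2)c2ccccc2)cc1` has not yet been measured. It differs from compound 2 by 1H-imidazol-1-yl in place of diethylamino on a saturated chain carbon, three bonds along the chain from two aromatic carbons. For the measured compounds named here, the one measured step replaces one amino substituent with another on the same chain carbon, whereas the step to compound 3 removes the amino substituent altogether, so that step is at best a weak guide; no measured pair shows what such an exchange does here. The expectation is nonetheless a move toward higher numbers, that is weaker inhibition, of roughly a 10-fold higher number from compound 2 to compound 3 (1.01 log units; beyond the scatter). Compound 3 is therefore estimated at 2000 nM, with a range from 500 nM to 10000 nM.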

Compound 3, antagonist equilibrium constant: 89.1 nM
Compound 3: middle estimate off by 22-fold (1.35 log units), on the high side; the measured number lies below the stated range.
By their numbers in this assay, from the lowest: compound 3; then compound 2; then compound 1.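

In this assay, among the compounds shown here, the earlier compounds showed this place, on a saturated chain carbon, three bonds along the chain from two aromatic carbons, carrying only open-chain amino groups, whereas 1H-imidazol-1-yl now shows that a five-membered aromatic ring with 2 hetero atoms can stand there with stronger inhibition. Exchanging diethylamino for this ring, at an equal count of 5 heavy atoms, gives a 2.2-fold lower number from compound 2 to compound 3 (0.34 log units; beyond the scatter) and the same ring in place of (tert-butyl)amino gives an 8.9-fold lower number from compound 1 to compound 3 (0.95 log units; beyond the scatter) so the ring ranks ahead of both amino groups. No supporting measurement accounts for this gain.

The compounds shown leave open whether the gain belongs to 1H-imidazol-1-yl itself or would also appear with a 1H-pyrrol-1-yl or 1H-pyrazol-1-yl group at this place. They also leave open how this assay would read a longer chain carrying the same ring.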